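Methyl Step on Thiadiazole Core of Thiophene Series

A few compounds are considered here, and "the series" means these few. Any claim that something is new, unique, unknown or untested is made for them only; others in the source may bear on it.

Compound 1 `O=C(NNC(=S)Nc1csc(-c2ccccc2)c1)c1ccc(O)cc1` gives 40000 nM in a functional assay on B16-F10 cells (Mus musculus) for inhibition, read by colorimetric assay and MTT assay, with a stated time of 72 h; a lower number here means a stronger inhibitor, a higher number a weaker inhibitor. Compound 2 `Cc1ccc(-c2cc(NC(=S)NNC(=O)c3ccc(O)cc3)cs2)cc1` gives 48000 nM in this assay; the change methyl in place of hydrogen on an aromatic carbon made the step of a 1.2-fold higher number from compound 1 to compound 2 (0.08 log units; within the scatter). Compound 3 `Oc1ccc(-c2nnc(Nc3csc(-c4ccccc4)c3)s2)cc1` gives 8000 nM in this assay, the lowest number among the three; the difference between the core of compound 3 and the core of compound 1 is not broken down here. Compound 4 `Cc1ccc(-c2cc(Nc3nnc(-c4ccc(O)cc4)s3)cs2)cc1` is not yet measured. It carries the change (methyl in place of hydrogen on an aromatic carbon), the same change as from compound 1 to compound 2, at a place described in the same words. Among the measured compounds shown here, the only precedent for this change is the step of a 1.2-fold higher number from compound 1 to compound 2 (0.08 log units; within the scatter). Resting on that one precedent only, the expected step is a 1.2-fold higher number from compound 3 to compound 4 (0.07 log units; within the scatter). Compound 4 is estimated at 9500 nM, between 4000 nM and 22000 nM.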

Compound 4, half-maximal inhibitory concentration: 6000 nM
The estimate for compound 4 lay 1.6-fold (0.20 log units) above the measured number; the range from low to high includes it.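

On the second core, phenyl to 4-methylphenyl gives a 1.3-fold lower number from compound 3 to compound 4 (0.12 log units; within the scatter), so the methyl leaves no step beyond the scatter here either. Set beside the earlier step, the two cores agree in this assay: the same change on two cores in this assay, a 1.2-fold higher number (0.08 log units; within the scatter) from compound 1 to compound 2 and a 1.3-fold lower number (0.12 log units; within the scatter) from compound 3 to compound 4, 1.6-fold (0.20 log units) apart, within the scatter of two such steps. This shows that the methyl carries from one core to the other at this one place, but with both steps this small, it does not show whether a change with a larger step would carry over, and it says nothing outside this assay.

Still open, on these data alone, is how a chlorine, a methoxy group or an amine at the same place would behave. Also open, as far as these compounds go, is whether a carboxylic acid or a longer chain would give matching steps on the two cores.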